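The source may report more compounds than this note shows. Statements on the series, on what has been measured and on what is new or still open speak of the compounds shown alone.

Compound 1, `COC(=O)c1cc(-c2cccc(NC(=O)c3ccc(/C=C/C(=O)c4cccc(F)c4)cc3)c2)on1`: in an ADME assay on Vero cells (Chlorocebus sabaeus) for cytotoxicity, read by MTT assay, with a stated time of 72 h (on this read-out higher numbers stand for lower toxicity in this test and lower numbers for higher toxicity in this test), compound 1 gives > 40 ug/mL, which is a limit of the assay rather than a number.
Compound 2, `COC(=O)c1cc(-c2cccc(NC(=O)c3ccc(/C=C/C(=O)c4cccs4)cc3)c2)on1`: in this assay compound 2 gives "not determined" (no result reported).
Compound 3, `COC(=O)c1cc(-c2cccc(NC(=O)c3ccc(/C=C/C(=O)c4ccccc4C)cc3)c2)on1`: in this assay compound 3 gives > 25 ug/mL, again a limit of the assay.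

Compound 3 therefore stands at a limit, with no single number of its own. The only other result shown for a compound in this assay is also a limit, and compound 2 has no result at all, so nothing here ranks the compounds against one another.

Compound 4, `COC(=O)c1cc(-c2cccc(NC(=O)c3ccc(/C=C/C(=O)c4ccc(Cl)cc4Cl)cc3)c2)on1`, differs from compound 3 in one place: 2,4-dichlorophenyl in place of 2-methylphenyl on a carbonyl carbon. Among the compounds with values here, the one measured step that bears on a change at this carbonyl carbon is a step that the two limits leave unreadable from compound 1 to compound 3; it is unreadable because each end rests on a limit, namely the limit of > 25 ug/mL in this assay, at which 1 of the 3 values shown sits, and (the limit of > 40 ug/mL in this assay, at which 1 of the 3 values shown sits). With nothing in these data to show movement in this assay, no step beyond the usual scatter is expected from compound 3 to compound 4, which is written as a step that the limit leaves unreadable from compound 3 to compound 4. Compound 4 is thus estimated at 40 ug/mL, within a range from 15 ug/mL to 80 ug/mL, and it may well again be reported only as a limit.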

Compound 4, half-maximal cytotoxic concentration: > 40 ug/mL
Compound 4 was reported as a limit; the forecaster's own chance of this, stated with the estimate: 70%; the middle value sits exactly at the limit.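

Compound 4, like compound 1 and compound 3, rests on a limit in this assay, and so no step can be read from compound 3 to compound 4 or from compound 1 to compound 4: the limit of > 40 ug/mL in this assay, at which 2 of the 4 values shown sit.

The compounds shown leave open whether swapping 3-fluorophenyl, 2-methylphenyl or 2,4-dichlorophenyl on the carbonyl carbon changes the result in this assay at all.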